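A Pyrimidinyl Sulfide Traded for a Cyclohexyl Sulfide

A few compounds are considered here, and "the series" means these few. Any claim that something is new, unique, unknown or untested is made for them only; others in the source may bear on it.

Of the compounds shown here, three have been measured. Within the data shown here, in a functional assay on U2OS cells (Homo sapiens) for antiproliferative activity, read by MTT assay, with a stated time of 72 h (on this read-out lower numbers stand for stronger inhibition and higher numbers for weaker inhibition), compound 1 `O=C(CSc1ncccn1)Nc1ccc2nc(NC(=O)c3ccc(C(F)(F)F)cc3)sc2c1` gives 28100 nM, the only reading that is a number among the three. Compound 2 `O=C(CSc1nnc(NC(=O)COc2ccccc2)s1)Nc1ccc(Br)cc1` returns only a limit, > 100000 nM. Compound 3 `CC(O)c1cccc(NC(=O)c2cc(Br)ccc2Br)c1` also returns only a limit, > 100000 nM. Compound 1 therefore stands alone with a number, while the limit of > 100000 nM in this assay, at which 2 of the 3 values shown sit, describes where the other two sit. Compound 4 `O=C(CSC1CCCCC1)Nc1ccc2nc(NC(=O)c3ccc(C(F)(F)F)cc3)sc2c1` shares the core of compound 1 and differs in one place: cyclohexyl in place of pyrimidin-2-yl on a sulfur. Among the measured compounds shown here, no step between measured compounds exists to weigh this change, so compound 4 is expected to move in this assay by no more than the usual scatter, a 1.1-fold higher number from compound 1 to compound 4 (0.03 log units; within the scatter). Compound 4 is accordingly estimated at 30000 nM, between 9000 nM and 100000 nM.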

Compound 4, half-maximal inhibitory concentration: 12300 nM
For compound 4 the middle estimate is 2.4-fold (0.39 log units) above the measured one, and the stated range covers the measured number.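

In this assay, among these compounds, the first step at this position shows that the sulfur's substituent does affect the reading: cyclohexyl in place of pyrimidin-2-yl gives a 2.3-fold lower number from compound 1 to compound 4 (0.36 log units; beyond the scatter). A ring of carbon only, with 0 hydrogen-bond acceptors, thus serves better here than the aromatic ring with 2 hetero atoms. Nothing shown accounts for this step.

On these data alone, whether the saturated ring or the loss of the ring nitrogens drives the shift remains open. Phenyl on the same sulfur would separate the two, and a longer chain would show whether a ring is needed at all.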